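The source may report more compounds than this note shows. Statements on the series, on what has been measured and on what is new or still open speak of the compounds shown alone.

Compound 1, `COc1cc(-c2nn(-c3cccc(NC(=O)c4ccc(Cl)c(C(F)(F)F)c4)c3)cc2-c2ccncc2)ccc1Cl`, is the weakest grower-inhibitor among the three compounds measured in a functional assay on OVCAR-3 cells (Homo sapiens) for inhibition, read by sulforhodamine B assay, with a stated time of 48 h; on this read-out higher numbers stand for weaker inhibition of growth and lower numbers for stronger inhibition of growth: there compound 1 gives 2420 nM. Two ureas built on a related core sit below it. Compound 2, `O=C(Nc1cccc(-n2cc(-c3ccncc3)c(-c3ccc(Cl)c(O)c3)n2)c1)Nc1cccc(C(F)(F)F)c1`, gives 1060 nM in this assay, and compound 3, `O=C(Nc1cccc(-n2cc(-c3ccncc3)c(-c3ccc(Cl)c(O)c3)n2)c1)Nc1ccc(Cl)c(C(F)(F)F)c1`, gives 830 nM. For the measured compounds named here, the only single-point step among them, a 1.3-fold lower number from compound 2 to compound 3 (0.11 log units; within the scatter), is a chloro in place of hydrogen on an aromatic carbon and falls within the scatter, so on its own it supports no direction.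

Compound 4, `COc1cc(-c2nn(-c3cccc(NC(=O)Nc4ccc(Cl)c(Cl)c4)c3)cc2-c2ccncc2)ccc1Cl`, keeps the core of compound 1 and differs from it in one place: (3,4-dichlorophenyl)amino in place of 4-chloro-3-(trifluoromethyl)phenyl on a carbonyl carbon. The change therefore does two things at once: the amide becomes a urea, and the trifluoromethyl gives way to a second chloro. The chloro-for-something part has a precedent in the step from compound 2 to compound 3, which stayed inside the scatter. Going by the values given here, the amide-to-urea part has no single-point precedent; all that can be said is that the two ureas, compound 2 and compound 3, show lower numbers than the amide compound 1, though they also carry a different substituent on their core. Weighing this, compound 4 is expected to show a modestly lower number than compound 1, an expected step of a 2.0-fold lower number from compound 1 to compound 4 (0.30 log units; within the scatter). Compound 4 is thus estimated at 1200 nM, with a range from 400 nM to 3600 nM.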

Compound 4, concentration for 50% growth inhibition: 697 nM
The estimate for compound 4 lay 1.7-fold (0.24 log units) above the measured number; low and high end bracket the measured number.
By their numbers in this assay, from the lowest: compounds 4, 3 and 2 (each within the scatter of the next); then compound 1.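

For the compounds shown here, on a carbonyl carbon of the core of compound 1, putting (3,4-dichlorophenyl)amino in place of 4-chloro-3-(trifluoromethyl)phenyl gives a 3.5-fold lower number from compound 1 to compound 4 (0.54 log units; beyond the scatter) in this assay, so this position responds to a change beyond the scatter, which the only earlier step, a 1.3-fold lower number from compound 2 to compound 3 (0.11 log units; within the scatter), did not show. The change brings in a nitrogen carrying a hydrogen and takes out the trifluoromethyl, and the step records only the sum of these two edits, so it shows that the pair together lowers the number on this core but assigns no share to either. No measurement at hand bears on why the number moves.

The compounds shown leave open how much of the step belongs to the urea nitrogen and how much to the second chloro, a split that the core of compound 1 carrying a urea with 4-chloro-3-(trifluoromethyl)phenyl would settle. They also leave open how this place would read with a carbamate oxygen or an N-methyl urea nitrogen in place of the nitrogen that entered, or with a bromo in place of either chloro on the ring.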